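Swapping the ring amine on compound 2

The source may report more compounds than this note shows. Statements on the series, on what has been measured and on what is new or still open speak of the compounds shown alone.

Measured in a functional assay on MES-SA/Dx5 cells (Homo sapiens) for inhibition, with a stated time of 72 h, in the presence of a further agent that is not named here; a higher number here means a weaker inhibitor, a lower number a stronger inhibitor:
- compound 1 `Oc1c(CN2CCCC2)cc(Br)c2cccnc12`: 2690 nM
- compound 2 `CCOCc1cc(CN2CCCC2)c(O)c2ncccc12`: 5250 nM

Compound 2, at 5250 nM, lies within the scatter of compound 1. Compound 3 `CCOCc1cc(CN2CCC(C)CC2)c(O)c2ncccc12` has 4-methylpiperidin-1-yl in place of pyrrolidin-1-yl on a saturated chain carbon bound to an aromatic carbon. Among the compounds with values here, the only measured step is a 2.0-fold higher number from compound 1 to compound 2 (0.29 log units; within the scatter), which exchanges bromo for ethoxymethyl on an aromatic carbon. Both measured compounds carry pyrrolidin-1-yl, so no measurement tests this swap, and no change beyond the scatter is expected in this assay. The expected step is a 1.3-fold lower number from compound 2 to compound 3 (0.12 log units; within the scatter). For compound 3 the estimated value is 4000 nM, with an expected range of 1500 nM to 10000 nM.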

Compound 3, half-maximal inhibitory concentration: 3020 nM
Compound 3: the middle estimate sits 1.3-fold (0.12 log units) above what was measured; the range from low to high includes it.
By their numbers in this assay, from the lowest: compounds 1, 3 and 2 (each within the scatter of the next).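

Within the data shown here, the swap from pyrrolidin-1-yl to 4-methylpiperidin-1-yl gives a 1.7-fold lower number from compound 2 to compound 3 (0.24 log units; within the scatter) in this assay and is the first change tested at this place, a saturated chain carbon bound to an aromatic carbon. A six-membered ring carrying a methyl group is therefore tolerated here as well as the five-membered ring, with no change beyond the scatter. No measured evidence bears on this result.

Still open, as far as these compounds go, is whether morpholin-4-yl, with an oxygen in the ring, or an open-chain diethylamino group would also leave the number within the scatter. From the compounds shown here alone, it is also open whether 4-methylpiperidin-1-yl would behave the same with bromo in place of ethoxymethyl.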